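The compounds below may be only part of what the source reports. "The series", "measured", "known", "first", "only" and "open" are said of these compounds alone.

Measured in a physicochemical assay for solubility, read by spectrophotometry, measured as kinetic solubility, at pH 8, tested at 500 uM; on this read-out lower numbers stand for lower solubility and higher numbers for higher solubility:
- Compound 1 `CN1CCC(NC(=O)c2ccncc2Nc2cc(-c3ccc4ccn(C)c4c3)c3nccnc3c2)CC1`: 246 ug/mL
- Compound 2 `CN1CCC(NC(=O)c2ccncc2Nc2cc(-c3ccc4ccn(C)c4c3)c3nccnc3c2)CC1=O`: 48 ug/mL
- Compound 3 `CC(=O)N1CCCC(NC(=O)c2ccncc2Nc2cc(-c3ccc4ccn(C)c4c3)c3nccnc3c2)C1`: 212 ug/mL

Compound 3, at 212 ug/mL, cannot be told apart from compound 1, and both stand above compound 2. Compound 4 `Cn1ccc2ccc(-c3cc(Nc4cnccc4C(=O)NCC4COCCN4)cc4nccnc34)cc21` carries (morpholin-3-yl)methyl in place of 1-acetylpiperidin-3-yl on an amide-type nitrogen.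

Among the measured compounds shown here, no measured step makes this exact exchange, so the evidence is indirect. All three measured steps change the group at this same nitrogen. The step of a 1.2-fold lower number from compound 1 to compound 3 (0.06 log units; within the scatter) shows that a large change of group there can leave the number unmoved. Compound 2 is the exception, seen in the modest step of a 5.1-fold lower number from compound 1 to compound 2 (0.71 log units; beyond the scatter) and in the step of a 4.4-fold higher number from compound 2 to compound 3 (0.65 log units; beyond the scatter). For the measured compounds named here, with only one of the three compounds standing apart, no change beyond the scatter is expected in this assay, though a modest drop cannot be excluded. The expected change is a 1.1-fold lower number from compound 3 to compound 4 (0.05 log units; within the scatter), an estimate that stays close to compound 3. The estimated value for compound 4 is 190 ug/mL, with an expected range of 90 ug/mL to 260 ug/mL.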

Compound 4, solubility: 239 ug/mL
Compound 4: the middle estimate sits 1.3-fold (0.10 log units) below what was measured; the measured number falls inside the stated range.
By their numbers in this assay, from the lowest: compound 2; then compounds 3, 4 and 1 (each within the scatter of the next).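

In this assay, another change of group on the amide-type nitrogen leaves the number unmoved, with a 1.1-fold higher number from compound 3 to compound 4 (0.05 log units; within the scatter) and a 1.0-fold lower number from compound 1 to compound 4 (0.01 log units; within the scatter), so the (morpholin-3-yl)methyl group joins 1-methylpiperidin-4-yl and 1-acetylpiperidin-3-yl in one band of values. Among the compounds shown here, compound 2 remains the only one that stands apart, with a 5.0-fold higher number from compound 2 to compound 4 (0.70 log units; beyond the scatter), which leaves 1-methyl-2-oxopiperidin-4-yl as the sole group of these four with a number separated from the rest. Nothing measured here accounts for that separation or for the agreement among the other three.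

The compounds shown leave open whether the band holds for a carboxylic acid or a longer chain ending in an amine on this nitrogen. They also leave open whether a ring carbonyl added to the (morpholin-3-yl)methyl group would lower the number as it does in compound 2.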